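Tertiary Amine in Place of a Secondary One

The source may hold more compounds than are shown below. What is called first, only, known or untested is meant among the compounds shown, and "the series" means these compounds.

Compound 3 `CCC(CC)Nc1nc(C)nc2c(-c3cnc(N(C)C)cc3C)c(C)nn12` gives 24.8 nM in an assay on cell membranes for displacement of a labelled ligand from corticotropin-releasing factor receptor 1 (Rattus norvegicus) (a higher number here means a weaker inhibitor, a lower number a stronger inhibitor), the second highest of the three numbers recorded. Compound 1 `CCC(CC)Nc1nc(C)nc2c(-c3c(C)cc(N(C)C)nc3C)c(C)nn12` gives 25.6 nM, and the two lie within the scatter of each other; the step from compound 1 to compound 3, hydrogen in place of methyl on an aromatic carbon, is a 1.0-fold lower number from compound 1 to compound 3 (0.01 log units; within the scatter). For the measured compounds named here, compound 2 `CCCCN(C)c1nc(C)nc2c(-c3ccc(OC)nc3C)c(C)nn12` gives 8.1 nM, a lower number than compound 3 beyond the scatter, but compound 2 differs from compound 3 in more than one place, so no single step connects them.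

Compound 4 `CCN(CC)c1nc(C)nc2c(-c3cnc(N(C)C)cc3C)c(C)nn12` differs from compound 3 by diethylamino in place of (pentan-3-yl)amino on an aromatic carbon. Going by the values given here, the only measured step, that from compound 1 to compound 3, concerns a different group elsewhere on the core and so does not bear on this change. Compound 2 also carries a tertiary amine on its core and gives a low number, but other parts of its structure differ as well, so it offers only a loose hint. A step of a 1.0-fold higher number from compound 3 to compound 4 (0.00 log units; within the scatter) is therefore expected, with no strong direction. Compound 4 is estimated at 25 nM, with a range from 8 nM to 80 nM.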

Compound 4, half-maximal inhibitory concentration: 13.8 nM
Beside the measured number, compound 4's estimate is 1.8-fold (0.26 log units) above it; the range from low to high includes it.
By their numbers in this assay, from the lowest: compounds 2, 4, 3 and 1 (each within the scatter of the next, the first and the last beyond it).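

For the compounds shown here, this is the first step read at this position, on an aromatic carbon between two ring nitrogen atoms, since the only earlier step concerned a methyl group elsewhere on the shared core. In this assay, diethylamino in place of (pentan-3-yl)amino gives a 1.8-fold lower number from compound 3 to compound 4 (0.25 log units; within the scatter), so the result stays within the scatter even though the count of hydrogen-bond donors in the group goes from 1 to 0 and the group loses a heavy atom; for this pair, then, the assay does not separate a secondary amine at this position from a tertiary one. Nothing at hand accounts for this result or says what the amine hydrogen contributes, if anything.

The compounds shown leave open whether a longer chain such as dipropylamino, or a cyclic amine such as pyrrolidine or morpholine, would also remain within the scatter of compound 4 at this position. They also leave open whether the same exchange of (pentan-3-yl)amino for diethylamino would read the same way on the core of compound 1, which carries its extra methyl group.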